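Hydroxy-to-methoxy step on the oxime series

A few compounds are considered here, and "the series" means these few. Any claim that something is new, unique, unknown or untested is made for them only; others in the source may bear on it.

Going by the values given here, compound 1 `Cc1cccc(/C(=N\O)C(O)CN2CCN(c3ccccn3)CC2)c1` is the lower of the two measured members: in a functional assay on HEK293 cells with D(4) dopamine receptor (Homo sapiens) as the target, read by FLIPR (a higher number here means a larger maximal response, a lower number a smaller maximal response), compound 1 gives 66%. Compound 2 `Cc1cccc(/C(=N/O)C(O)CN2CCN(c3ccccn3)CC2)c1` is its double-bond counterpart, and in this assay compound 2 gives 81%. Among the compounds with values here, the one measured step, a number 15 percentage points higher from compound 1 to compound 2 (beyond the scatter), concerns only the drawing of the double bond; the single note attached to that pair is the fact that one of compounds 1 and 2 is drawn with a defined configuration and the other without, at the place where they differ. Compound 3 `COC(CN1CCN(c2ccccn2)CC1)/C(=N/O)c1cccc(C)c1` differs from compound 1 by methyl in place of hydrogen on an oxygen on a saturated carbon. Within the data shown here, no measured step touches the hydroxy group, so the one step on record gives no guidance on the direction or size of this change, and the expectation rests on the starting value alone. Compound 3 is therefore estimated to sit near compound 1, at 63%, within a wide range from 35% to 88%. The step this estimate implies is a number 3 percentage points lower from compound 1 to compound 3 (within the scatter), expected to remain within the scatter.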

Compound 3, largest response reached (reported as efficacy), in percent of the reference or control that the assay uses: 53%
Estimate against measurement, compound 3: 10 percentage points above; the range from low to high includes it.
By their numbers in this assay, from the lowest: compound 3; then compound 1; then compound 2.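

In this assay the hydroxy to methoxy change is not silent at this place, on an oxygen on a saturated carbon (a number 13 percentage points lower from compound 1 to compound 3 (beyond the scatter)). Going by these compounds alone, this is the first reading at that oxygen, and it shows that the hydrogen there can be replaced by methyl with a substantial response retained, as compound 3 still gives 53% in the same read-out. Nothing on record bears on why this change lowers the response.

As far as these compounds go, whether the loss belongs to methyl specifically or to any replacement of that hydrogen stays open, and an ethyl ether, an acetate ester or an amine at the same carbon would separate those readings. Also open, from the compounds shown here alone, is whether the same methyl in place of hydrogen gives a step of similar direction and size on compound 2, the double-bond counterpart.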